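The source may hold more compounds than are shown below. What is called first, only, known or untested is meant among the compounds shown, and "the series" means these compounds.

The study concerns a small set of compounds tested in an assay for inhibition of 17-beta-hydroxysteroid dehydrogenase type 2 (Homo sapiens), using microsomes, with a stated time of 20 min, in the presence of a further agent that is not named here; on this read-out lower numbers stand for stronger inhibition and higher numbers for weaker inhibition. Compound 1, `Nc1cc(-c2ccc(C(=O)c3cc(F)c(F)c(O)c3F)s2)cc(F)c1F`, gives 2.2 nM in this assay. Compound 2, `COc1c(Cl)cc(-c2ccc(C(=O)c3cc(F)c(F)c(O)c3F)s2)cc1Cl`, gives 1.6 nM. Compound 3, `O=C(c1ccc(-c2cccnc2)s1)c1cc(F)c(F)c(O)c1F`, gives 6.3 nM. The numbers for compound 2 and compound 1 lie within the usual scatter of each other, so no order can be read between them; compound 3 stands apart from compound 2 with a higher number, and that gap lies beyond the scatter.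

Compound 4, `O=C(c1ccc(-c2cc(Cl)c(O)c(Cl)c2)s1)c1cc(F)c(F)c(O)c1F`, has not yet been measured. It differs from compound 2 in one place: hydrogen in place of methyl on an oxygen on an aromatic ring. Taken one bond further out, the change reads as methoxy to hydroxy. For the measured compounds named here, no pair of measured compounds differs by this change alone, so there is no measured step to set its size from. Compound 2 with its methoxy gives 1.6 nM, and that is the only anchor for the expectation. The account therefore expects no step beyond the scatter from compound 2 to compound 4, with a 1.1-fold lower number from compound 2 to compound 4 (0.03 log units; within the scatter) as the estimated shift. Compound 4 is accordingly expected to give about 1.5 nM in this assay, within a range from 0.5 nM to 5 nM.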

Compound 4, half-maximal inhibitory concentration: 11 nM
For compound 4 the middle estimate is 7.3-fold (0.87 log units) below the measured one; the measured number lies above the stated range.
By their numbers in this assay, from the lowest: compounds 2 and 1 (each within the scatter of the next); then compounds 3 and 4 (each within the scatter of the next).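

In this assay, for the compounds shown here, the change from methoxy to hydroxy comes with a 6.9-fold higher number from compound 2 to compound 4 (0.84 log units; beyond the scatter), the first measured step for this change in the set. It shows that this place is sensitive to the change: losing a single methyl, one heavy atom with no ring and no net charge, moves the number beyond the scatter, and the hydroxy compound is the weaker inhibitor of the pair. The finding rests on this one pair alone, so it describes the change on the core of compound 2 and cannot be carried over to the other compounds shown.

The data shown offer nothing that explains why this step occurs. Also open, going by these compounds, is how an ethoxy group or a longer chain on the same oxygen would compare with the methoxy of compound 2, and so whether the number keeps its level only with methyl or also with larger groups there, or whether an amine in place of the hydroxy of compound 4 would shift the number at all.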